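The source may report more compounds than this note shows. Statements on the series, on what has been measured and on what is new or still open speak of the compounds shown alone.

Compound 1 `CCN(Cc1cccs1)C(=O)COc1ccc(C)cc1`: 8 nM
Compound 2 `CCCc1ccc(OCC(=O)N(CC)Cc2cccs2)cc1`: 1810 nM

In an assay on HEK293 cells for agonist activity at transient receptor potential cation channel subfamily M member 8 (Homo sapiens), read by fluorescence and calcium flux, with a stated time of 15 min (on this read-out higher numbers stand for an effect only at larger amounts of compound and lower numbers for an effect already at smaller amounts), compound 2 gives the higher of the two numbers; compound 1 gives 8 nM, and the step of a 230-fold higher number from compound 1 to compound 2 (2.35 log units; beyond the scatter) is large. Compound 3 `CCN(Cc1cccs1)C(=O)COc1ccc(C(C)C)cc1` differs from compound 2 by isopropyl in place of propyl on an aromatic carbon. No measured step bears directly on this change, since the only step shown exchanges hydrogen for ethyl on a chain carbon rather than rearranging a chain of the same size. The expected step of a 1.5-fold lower number from compound 2 to compound 3 (0.18 log units; within the scatter) is therefore small. Compound 3 is estimated at 1200 nM in this assay, within 250 nM to 6000 nM.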

Compound 3, half-maximal effective concentration: 397 nM
Estimate against measurement, compound 3: 3.0-fold (0.48 log units) above; the range from low to high includes it.
By their numbers in this assay, from the lowest: compound 1; then compound 3; then compound 2.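

In this assay, moving between two groups of the same atoms at this position, para to a large group, gives a 4.6-fold lower number from compound 2 to compound 3 (0.66 log units; beyond the scatter) and lies beyond the scatter, so the arrangement of the three carbons counts here and not only their number. The branched group does not recover the methyl result, since a 50-fold higher number from compound 1 to compound 3 (1.70 log units; beyond the scatter) still separates the two compounds. Nothing available explains either step. From the compounds shown here alone, whether ethyl, tert-butyl or cyclopropyl on this aromatic carbon would stand nearer to methyl or to isopropyl remains open.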